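A few compounds are considered here, and "the series" means these few. Any claim that something is new, unique, unknown or untested is made for them only; others in the source may bear on it.

Values in a functional assay on HCT-116 cells (Homo sapiens) for inhibition, read by MTT assay, with a stated time of 48 h; a lower number here means a stronger inhibitor, a higher number a weaker inhibitor:

Compound 1 `Clc1ccccc1CSc1nnc(-c2ccncc2)n1-c1ccccc1`: 13900 nM
Compound 2 `O=[N+]([O-])c1ccccc1CSc1nnc(-c2ccncc2)n1-c1ccccc1`: > 50000 nM
Compound 3 `O=C(CSc1nnc(-c2ccncc2)n1-c1ccccc1)N/N=C/c1ccc(O)cc1`: > 50000 nM

Compound 1 is the only one of the three with a number. Compound 2 reports only a limit of the assay. Going by these compounds, compound 3 likewise reports only a limit and stands at the limit of > 50000 nM in this assay, at which 2 of the 3 values shown sit, so its true value is unknown beyond that.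

Compound 4 `O=C(CSc1nnc(-c2ccncc2)n1-c1ccccc1)N/N=C/c1cccc(F)c1` differs from compound 3 by 3-fluorophenyl in place of 4-hydroxyphenyl on a carbon with a double bond to nitrogen. Among the compounds with values here, the single measured step, an at least 3.5-fold higher number from compound 1 to compound 2 (0.55 log units; beyond the scatter), concerns a different exchange at a different place and gives no guidance for this one. Within the data shown here, no measured step bears on the change from compound 3 to compound 4.

Compound 4 is therefore expected to remain at or near the limit, estimated at 50000 nM with a range from 20000 nM to 120000 nM. The expected step is a number no higher from compound 3 to compound 4 (the limit leaves the size open), within the scatter.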

Compound 4, half-maximal inhibitory concentration: > 50000 nM
Compound 4: no number, only a limit; the forecaster's own chance of this, stated with the estimate: 70%; the middle value lies on the limit itself.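

Compound 3 and compound 4 both give only a limit in this assay, so no step between them can be read: the limit of > 50000 nM in this assay, at which 3 of the 4 values shown sit.

The compounds shown leave open how 3-fluorophenyl and 4-hydroxyphenyl compare in this series.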